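Pyridine to pyrazine at the aryl ether of compound 2

This account rests on a few compounds, and the source may have more. Where it says the series, first, only, none or still open, it means among the compounds named here.

This account concerns a small set of aryl ethers built on a common core and measured in a functional assay on isolated protein for agonist activity at Glucose-dependent insulinotropic receptor (Homo sapiens), read by HTRF and cAMP accumulation; a higher number here means that more compound is needed for the effect, a lower number that less compound is needed. Compound 1 `CC(C)(C)OC(=O)N1CCC(O[C@H]2CC[C@H](Oc3ccc(C#N)cc3)CC2)CC1` gives 8.6 nM. Compound 2 `CC(C)(C)OC(=O)N1CCC(O[C@H]2CC[C@H](Oc3ccc(S(C)(=O)=O)cn3)CC2)CC1` gives 47 nM. Among the compounds with values here, the only step recorded so far, a 5.5-fold higher number from compound 1 to compound 2 (0.74 log units; beyond the scatter), is the exchange of 5-(methylsulfonyl)pyridin-2-yl for 4-cyanophenyl on an oxygen on a saturated carbon. Among the two numbers in this assay, compound 2 therefore holds the highest one, with compound 1 as its nearest neighbour at a clearly lower value.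

Compound 3 `CC(C)(C)OC(=O)N1CCC(O[C@H]2CC[C@H](Oc3cnc(S(C)(=O)=O)cn3)CC2)CC1` is not yet measured. It differs from compound 2 by 5-(methylsulfonyl)pyrazin-2-yl in place of 5-(methylsulfonyl)pyridin-2-yl on an oxygen on a saturated carbon. Within the data shown here, no recorded step bears directly on this change: the single step from compound 1 to compound 2 replaced a whole aryl group rather than swapping one ring nitrogen pattern for another, so it offers only a loose guide. Among the measured compounds shown here, with no closer precedent, the author expects compound 3 to give a number close to that of compound 2, with a step of a 1.5-fold higher number from compound 2 to compound 3 (0.17 log units; within the scatter) that may well lie within the scatter. The estimate for compound 3 in this assay is 70 nM, with a range from 25 nM to 200 nM.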

Compound 3, half-maximal effective concentration: 5.9 nM
Compound 3: the middle estimate sits 12-fold (1.07 log units) above what was measured, and the stated range ends above it.
By their numbers in this assay, from the lowest: compounds 3 and 1 (each within the scatter of the next); then compound 2.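

The pyrazine exchange gives an 8.0-fold lower number from compound 2 to compound 3 (0.90 log units; beyond the scatter) in this assay, so at this place, on an oxygen on a saturated carbon, the outcome depends on the aromatic ring itself even when the methylsulfonyl group stays the same. The earlier step, a 5.5-fold higher number from compound 1 to compound 2 (0.74 log units; beyond the scatter), could have been read as a penalty for the methylsulfonyl-bearing aryl group as a whole, but a 1.5-fold lower number from compound 1 to compound 3 (0.16 log units; within the scatter) shows that such a group can match 4-cyanophenyl within the scatter, and compound 2 alone carries the higher number. Nothing on hand accounts for the effect of this change on the ring.

These three compounds do not show whether the pyrazine benefit depends on the methylsulfonyl group or would persist with a carboxamide or an amine in its place. They also leave open whether the same ring exchange would have a similar effect if the tert-butyl carbamate on the shared core gave way to a different group, such as a simple acetyl.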